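The source may report more compounds than this note shows. Statements on the series, on what has been measured and on what is new or still open speak of the compounds shown alone.

Measured compounds:
- compound 1, `CCC(C)Sc1nc2c(cc(-c3ccccc3)n2-c2ccccc2)c(=N)s1`, which in a functional assay on the whole organism for inhibition, with Rattus norvegicus as the target, read by ELISA, with stated times of 30 min and 6 h, at a dose of 30 mg/kg by the oral route (on this read-out higher numbers stand for more inhibition at the one dose given (going by the name of the read-out) and lower numbers for less inhibition), gives 50%
- compound 2, `CCn1c(=S)[nH]c2c(cc(-c3ccccc3)n2-c2ccccc2)c1=N`, which in this assay gives 65%

Compound 2 stands highest of the two numbers measured. Its nearest neighbour is compound 1, whose value lies lower by a margin beyond the usual scatter of this kind of measurement. Compound 3 `CCn1c(=S)[nH]c2c(cc(-c3ccc(C)cc3)n2-c2ccccc2)c1=N` has not yet been measured in this assay. It differs from compound 2 in a single place: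

methyl in place of hydrogen on an aromatic carbon

Among the measured compounds shown here, no pair of measured compounds separated by one change is available here; nothing in the measured set shows what this change does to the read-out. The expectation therefore rests on compound 2 alone. Compound 3 is expected to show a step of a number 3 percentage points lower from compound 2 to compound 3 (within the scatter) from compound 2, which is no change beyond the scatter. The estimate for compound 3 is 62%, with a range from 40% to 80%.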

Compound 3, a percentage reported as inhibition, in the whole organism at one dose (the size of the read-out at that dose, not a potency): 60%
The estimate for compound 3 lay 2 percentage points above the measured number; the measured number falls inside the stated range.
By their numbers in this assay, from the lowest: compounds 1, 3 and 2 (each within the scatter of the next, the first and the last beyond it).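

In this assay, methyl in place of hydrogen on an aromatic carbon, para to a large group, gives a number 5 percentage points lower from compound 2 to compound 3 (within the scatter). This is the first single change that can be read among these compounds, and it shows that going from phenyl to 4-methylphenyl, which adds one carbon at this position, moves the inhibition at the one dose by no more than the scatter. Nothing at hand bears on the reason for this result.

From the compounds shown here alone, whether a longer chain, a methoxy group, a chlorine atom, an amine or a carboxylic acid at this same position would also leave the read-out level remains open. Going by these compounds, it is equally open whether methyl would give a similar step on the other phenyl group of the shared core.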